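Adding a Dimethylamino Group to Compound 2

The source may hold more compounds than are shown below. What is called first, only, known or untested is meant among the compounds shown, and "the series" means these compounds.

Measured compounds:
compound 1 `Nc1ccnc2cc(C#Cc3c(F)cccc3F)ccc12`: 23.6%
compound 2 `Fc1cccc(F)c1C#Cc1cncc2ccccc12`: 16.5%

Of the compounds shown here, two have been measured so far in a functional assay on LS174T cells (Homo sapiens) for inhibition, with a stated time of 4 days, tested at 1 uM; on this read-out lower numbers stand for a weaker effect and higher numbers for a stronger effect at the one concentration tested. Compound 1 gives 23.6%, and compound 2 gives 16.5%. These two numbers sit close together; the gap between them lies within the usual scatter of repeated measurements, so neither compound can be called stronger or weaker than the other. Compound 2 holds the lower of the two numbers, but only by a margin that repeated testing could erase.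

Compound 3 `CN(C)c1ncc(C#Cc2c(F)cccc2F)c2ccccc12` is the next compound to be tested. It comes from compound 2 by a single change: dimethylamino in place of hydrogen on an aromatic carbon. For the measured compounds named here, no measured pair in this set shows what such a change does on this read-out, so there is nothing to lean on beyond the two numbers already in hand. Both of those numbers are modest, and a single small group is not expected to move the read-out far. The step of a number 3.5 percentage points higher from compound 2 to compound 3 (within the scatter) is therefore expected to be small, with no clear direction beyond the scatter. Compound 3 is estimated to give about 20%, within a range from 2% to 45%.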

Compound 3, a percentage reported as inhibition, at one concentration (the size of the read-out at that concentration, not a potency): 99.5%
Beside the measured number, compound 3's estimate is 79.5 percentage points below it; measured number above the stated range.
By their numbers in this assay, from the lowest: compounds 2 and 1 (each within the scatter of the next); then compound 3.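

In this assay, the aromatic carbon next to the ring nitrogen proves to be a highly sensitive place on the shared core: dimethylamino in place of hydrogen there gives a number 83 percentage points higher from compound 2 to compound 3 (beyond the scatter). For the compounds shown here, the earlier compounds offered no pair that tested a change at this place, so this is the first sign that one small group added to compound 2 can turn a modest read-out into a very strong one. The result comes from a single pair at one concentration, so it shows the size of the effect at that concentration rather than a potency, and nothing available here accounts for the jump.

The compounds shown leave open whether the effect needs dimethylamino itself or would also appear with a related group at the same carbon, such as methylamino, methoxy or a piperidine ring. They also leave open whether a longer chain carrying an amine at that place would keep, lose or change the effect, and whether the same change would act similarly on a different core.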